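The source may hold more compounds than are shown below. What is called first, only, known or untested is meant among the compounds shown, and "the series" means these compounds.

Measured in a functional assay on A2780 cells (Homo sapiens) for antiproliferative activity, read by MTT assay, with a stated time of 48 h; a higher number here means a weaker inhibitor, a lower number a stronger inhibitor:

Compound 1, `COc1ccc2c(/C=C/C(=O)c3cc(OC)c(OC)c(SC)c3)c[nH]c2c1`: 139 nM
Compound 2, `COc1ccc2c(/C=C/C(=O)c3cc(N)c(OC)c(OC)c3)c[nH]c2c1`: 204 nM
Compound 3, `COc1cc(C(=O)/C=C/c2cn(C)c3ccccc23)cc(SC)c1OC`: 193 nM

Compound 1 and compound 2 share a core and differ in one place, (amino in place of methylsulfanyl on an aromatic carbon); this change gave a 1.5-fold higher number from compound 1 to compound 2 (0.17 log units; within the scatter). Compound 3 carries a different core; the difference between the two cores is not broken down here, and its value in this assay lies within the scatter of both compound 1 and compound 2. Compound 4, `COc1cc(C(=O)/C=C/c2cn(C)c3ccccc23)cc(N)c1OC`, has not yet been measured. It differs from compound 3 by amino in place of methylsulfanyl on an aromatic carbon, the same change as that from compound 1 to compound 2. For the measured compounds named here, compound 4 is expected to give a 1.5-fold higher number from compound 3 to compound 4 (0.18 log units; within the scatter) because a 1.5-fold higher number from compound 1 to compound 2 (0.17 log units; within the scatter) is the only measured example of this change. The estimate for compound 4 in this assay is 290 nM, with a range from 150 nM to 550 nM.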

Compound 4, half-maximal inhibitory concentration: 441 nM
Estimate against measurement, compound 4: 1.5-fold (0.18 log units) below; the range from low to high includes it.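

In this assay, amino in place of methylsulfanyl on an aromatic carbon gave a 2.3-fold higher number from compound 3 to compound 4 (0.36 log units; beyond the scatter), a step that stands beyond the scatter, unlike the earlier one on the core of compound 1. Even so, the two steps cannot be told apart: the same change on two cores in this assay, a 1.5-fold higher number (0.17 log units; within the scatter) from compound 1 to compound 2 and a 2.3-fold higher number (0.36 log units; beyond the scatter) from compound 3 to compound 4, 1.6-fold (0.19 log units) apart, within the scatter of two such steps. The change thus carries from one core to the other as far as these two pairs can show, but two pairs do not establish that its size is the same on every core or that the core has no influence on it.

The compounds shown leave open how a hydroxyl, a dimethylamino or an acetamido group at this place would compare with amino and methylsulfanyl on either core. As far as these compounds go, whether the step holds on a third core also remains open.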